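This account rests on a few compounds, and the source may have more. Where it says the series, first, only, none or still open, it means among the compounds named here.

Measured in a functional assay on HL-60 cells (Homo sapiens) for cytotoxicity, read by luminescence and CellTiter-Glo, with a stated time of 3 days; on this read-out higher numbers stand for weaker inhibition and lower numbers for stronger inhibition:

- compound 1 `N#Cc1ccc(NC(=O)c2ccc(C(F)(F)F)cc2O)cc1`: 1030 nM
- compound 2 `O=C(Nc1ccc(C(F)(F)F)cc1)c1ccc(Br)cc1O`: 360 nM
- compound 3 `N#Cc1ccc(NC(=O)c2ccc(-c3ccccc3)cc2O)cc1`: 700 nM

Compound 3, at 700 nM, cannot be told apart from compound 1 or from compound 2, since both of its gaps lie within the usual scatter. The next compound to be measured is compound 4 `N#Cc1ccc(NC(=O)c2ccc(Br)cc2O)cc1`, which has bromo in place of phenyl on an aromatic carbon, so that the change from compound 3 reads (bromo in place of phenyl on an aromatic carbon).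

For the measured compounds named here, only one measured step concerns this same carbon. That step, a 1.5-fold lower number from compound 1 to compound 3 (0.17 log units; within the scatter), exchanged trifluoromethyl for phenyl and stayed within the scatter. Compound 2 also carries the bromo, at 360 nM, but it has trifluoromethyl where compound 4 has nitrile, so it offers only a loose guide. Going by the values given here, no measured pair shows the bromo exchanged on its own. No step beyond the scatter is therefore expected in this assay, and any shift is expected to be slightly towards a lower number. The expected change is a 1.2-fold lower number from compound 3 to compound 4 (0.07 log units; within the scatter). For compound 4 the estimated value is 600 nM, with an expected range from 260 nM to 1300 nM.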

Compound 4, half-maximal inhibitory concentration: 1210 nM
For compound 4 the middle estimate is 2.0-fold (0.30 log units) below the measured one; measured number inside the range.
By their numbers in this assay, from the lowest: compounds 2, 3, 1 and 4 (each within the scatter of the next, the first and the last beyond it).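

In this assay, bromo, phenyl and trifluoromethyl on this aromatic carbon, para to a large group, cannot be told apart while nitrile stays in place: a 1.7-fold higher number from compound 3 to compound 4 (0.24 log units; within the scatter) and a 1.2-fold higher number from compound 1 to compound 4 (0.07 log units; within the scatter) both stay within the scatter, like the earlier 1.5-fold lower number from compound 1 to compound 3 (0.17 log units; within the scatter). For the compounds shown here, the only step beyond the scatter involves the other substituent, for with bromo held fixed, the exchange of trifluoromethyl for nitrile gives a 3.4-fold higher number from compound 2 to compound 4 (0.53 log units; beyond the scatter), a modest change. Among these four compounds, the number therefore responds to that exchange and not to the three groups compared on the first carbon, although this rests on a single pair.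

From the compounds shown here alone, it remains open whether the exchange of trifluoromethyl for nitrile would give a similar step with phenyl on the first carbon, and whether an amine, a carboxylic acid or a methoxy group there would also stay within the scatter. Nothing available explains the size of any of these steps.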